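From phenyl to 4-methoxyphenyl in compound 1

The source may report more compounds than this note shows. Statements on the series, on what has been measured and on what is new or still open speak of the compounds shown alone.

Values in a functional assay on HT-29 cells (Homo sapiens) for antiproliferative activity, read by MTT assay, with a stated time of 48 h; a lower number here means a stronger inhibitor of growth, a higher number a weaker inhibitor of growth
- compound 1 `COC(=O)N1N=C(c2ccccc2)CC1c1cc(OC)c(OC)c(OC)c1`: 6260 nM
- compound 2 `CCOC(=O)N1N=C(c2ccccc2)CC1c1cc(OC)c(OC)c(OC)c1`: 8920 nM
- compound 3 `COc1cc(C2CC(c3ccccc3)=NN2C(=O)OCc2ccccc2)cc(OC)c1OC`: > 10000 nM (a limit of the assay)

Going by the values given here, compound 1 stands level with compound 2 within the scatter, and these are the only two numbers. The entry for compound 3 is a limit and not a number.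

The next compound is compound 4 `COC(=O)N1N=C(c2ccc(OC)cc2)CC1c1cc(OC)c(OC)c(OC)c1`, which carries methoxy in place of hydrogen on an aromatic carbon, para to a large group, so that phenyl becomes 4-methoxyphenyl: methoxy in place of hydrogen on an aromatic carbon.

The measured steps all sit on the saturated chain carbon bound to an oxygen next to a carbonyl group: a 1.4-fold higher number from compound 1 to compound 2 (0.15 log units; within the scatter), an at least 1.5-fold higher number from compound 1 to compound 3 (0.20 log units; that floor lies within the scatter) and an at least 1.1-fold higher number from compound 2 to compound 3 (0.04 log units; that floor lies within the scatter). Each lies within the scatter, or has a floor that does, and none touches the aromatic carbon changed here. The series holds no measured change at that place, so these steps give no direction and only weak guidance on size. No step beyond the scatter is therefore expected, in either direction.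

The expected outcome is a 1.0-fold lower number from compound 1 to compound 4 (0.02 log units; within the scatter), an estimate that stays within the scatter. For compound 4 the estimated value is 6000 nM, with an expected range from 2500 nM to 10000 nM.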

Compound 4, concentration for 50% growth inhibition: 2550 nM
The estimate for compound 4 lay 2.4-fold (0.37 log units) above the measured number; the measured number falls inside the stated range.
By their numbers in this assay, from the lowest: compound 4; then compounds 1 and 2 (each within the scatter of the next). At a limit, above all of these: compound 3.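

In this assay, going by these compounds alone, the step from hydrogen to methoxy gives a 2.5-fold lower number from compound 1 to compound 4 (0.39 log units; beyond the scatter), and it is the only step printed as beyond the scatter, though a modest one. Within the data shown here, the earlier steps all sat on the saturated chain carbon bound to an oxygen next to a carbonyl group, and each lay within the scatter or had a floor that did, so this aromatic carbon, para to a large group, is the first place to give a direction: phenyl to 4-methoxyphenyl lowers the number. Nothing shown here bears on why this change lowers the number, which rests on this single pair of compounds.

Still open, going by these compounds, is whether this position answers to methoxy in particular or to substitution in general, which a hydroxy group, an amine, a carboxylic acid or a longer chain such as ethoxy at the same carbon would begin to separate. Also open, on these data alone, is whether the same change would lower the number on the core of compound 2, which would show whether the step carries over to a different group on the chain side.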